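Fluoro-for-hydrogen steps across two related cores

The compounds below may be only part of what the source reports. "The series", "measured", "known", "first", "only" and "open" are said of these compounds alone.

Three compounds measured in a functional assay on CHO cells for agonist activity at Free fatty acid receptor 1 (Homo sapiens), read by FLIPR and calcium flux, in the presence of a further agent that is not named here; a lower number here means that less compound is needed, a higher number that more compound is needed for the effect:
compound 1, `O=C(O)CCc1ccc(OCc2ncc(-c3cccc(F)c3)o2)cc1`, gives 1070 nM
compound 2, `O=C(O)CCc1ccc(OCc2ncc(-c3ccccc3)o2)cc1`, gives 1600 nM
compound 3, `O=C(O)CCc1ccc(OCc2nc(-c3ccccc3)no2)cc1`, gives 1130 nM

Compound 3 sits with compound 1 and compound 2 within the scatter on either side, so no order among the three can be read. The difference between the core of compound 3 and the core of compound 2 is not broken down here.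

Compound 1 differs from compound 2 by fluoro in place of hydrogen on an aromatic carbon. This gave a 1.5-fold lower number from compound 2 to compound 1 (0.17 log units; within the scatter).

Compound 4, `O=C(O)CCc1ccc(OCc2nc(-c3ccc(F)cc3)no2)cc1`, is not yet measured. It differs from compound 3 by fluoro in place of hydrogen on an aromatic carbon. This is the same kind of change as that from compound 2 to compound 1, not the same: there the fluoro enters meta to a large group, here para to a large group, in each case on a six-membered aromatic ring of carbon only.

The expectation for compound 4 in this assay rests on compound 3 at 1130 nM and on a 1.5-fold lower number from compound 2 to compound 1 (0.17 log units; within the scatter). A step of similar size is expected, a 1.3-fold lower number from compound 3 to compound 4 (0.10 log units; within the scatter), with the changed place adding uncertainty. Compound 4 is estimated at 900 nM, between 400 nM and 2000 nM.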

Compound 4, half-maximal effective concentration: 680 nM
For compound 4 the middle estimate is 1.3-fold (0.12 log units) above the measured one, within the range that was stated.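

In this assay, fluoro in place of hydrogen on the phenyl of the core of compound 3 gives a 1.7-fold lower number from compound 3 to compound 4 (0.22 log units; within the scatter). Set beside the earlier step, the change reads alike on the two cores: the same change on two cores in this assay, a 1.5-fold lower number (0.17 log units; within the scatter) from compound 2 to compound 1 and a 1.7-fold lower number (0.22 log units; within the scatter) from compound 3 to compound 4, 1.1-fold (0.05 log units) apart, within the scatter of two such steps

This shows no sign that the core alters the step, but each step lies within the scatter on its own, so neither shows that fluoro changes the number at all, and agreement between two small steps is weak evidence that the change carries from one core to another. The fluoro also stands at a different place in each pair, so the core and the place are not separated here.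

The compounds shown leave open how the step reads with fluoro at one and the same place on both cores, and how chloro or trifluoromethyl on the phenyl compares with fluoro. They also leave open what a longer chain carrying the carboxylic acid would do on either core.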